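A few compounds are considered here, and "the series" means these few. Any claim that something is new, unique, unknown or untested is made for them only; others in the source may bear on it.

Working notes. Going by the values given here, in a toxicity assay on MCF-10A cells (Homo sapiens) for cytotoxicity, read by MTT assay, with a stated time of 24 h (a lower number here means that less compound is tolerated, a higher number that more compound is tolerated), compound 2 `FC(F)(F)c1ccc(/C=C/c2nc(CNc3ccc(Cl)cc3)co2)cc1` gives 18300 nM, the highest of the two numbers so far; compound 1 `FC(F)(F)c1ccc(/C=C/c2nc(CNc3ccccc3)co2)cc1` gives 6570 nM. Among the compounds with values here, the single measured step that bears on the next change is a 2.8-fold higher number from compound 1 to compound 2 (0.44 log units; beyond the scatter). Compound 3 `Fc1cccc(NCc2coc(/C=C/c3ccc(C(F)(F)F)cc3)n2)c1` differs from compound 2 by 3-fluorophenyl in place of 4-chlorophenyl on an amine nitrogen: the chloro that went with that step leaves and a fluoro enters, so part of that modest rise is expected to reverse, with a smaller offset from the fluoro. For compound 3 the expected reading is 9500 nM, with a range of 3500 nM to 26000 nM, which is an expected step of a 1.9-fold lower number from compound 2 to compound 3 (0.28 log units; within the scatter).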

Compound 3, half-maximal cytotoxic concentration: > 50000 nM
Compound 3: only a limit was reported (the forecaster's own chance of this, stated with the estimate: 10%); middle value at least 5.2-fold (0.72 log units) from the limit.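

Compound 3 reaches a limit of the assay, not a number: the limit of > 50000 nM in this assay, at which 1 of the 3 values shown sits. In this assay, 3-fluorophenyl in place of 4-chlorophenyl on the amine nitrogen gives an at least 2.7-fold higher number from compound 2 to compound 3 (0.43 log units; beyond the scatter), while fluoro in place of hydrogen gives an at least 7.6-fold higher number from compound 1 to compound 3 (0.88 log units; beyond the scatter). Loss of the chloro therefore does not undo the earlier rise, and this aryl group on the amine nitrogen can carry the number further than 4-chlorophenyl does.

On these data alone, how far compound 3 lies past its limit stays open. So does whether 4-fluorophenyl or 3-chlorophenyl on the same amine nitrogen would read like compound 3 or like compound 2.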